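This account rests on a few compounds, and the source may have more. Where it says the series, first, only, none or still open, it means among the compounds named here.

Measured compounds:
compound 1 `Cc1ccc(C(=O)Oc2ccc(O)c(C(C)(C)C)c2)cc1` — > 100000 nM
compound 2 `CC(C)(C)c1cc(NC(=O)c2c(Cl)cc(NCc3ccncc3)cc2Cl)ccc1O` — 9800 nM
compound 3 `CC(C)(C)c1cc(NC(=O)c2c(Cl)cc(NCc3cccs3)cc2Cl)ccc1O` — 8600 nM

In an assay on isolated protein for antagonist activity at Bile acid receptor (Homo sapiens), read by HTRF, with a stated time of 30 min (on this read-out lower numbers stand for stronger inhibition and higher numbers for weaker inhibition), compound 1 gives > 100000 nM, which is a limit of the assay and not a number. Compound 2 gives 9800 nM in this assay, and compound 3 gives 8600 nM. The two numbers sit close together: the step of a 1.1-fold lower number from compound 2 to compound 3 (0.06 log units; within the scatter) stays within the usual scatter, so the two compounds cannot be told apart on these data. Compound 3 is thus one of two compounds with a measured number, and the other, compound 2, stands within the scatter of it.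

Compound 4 `CC(C)(C)c1cc(NC(=O)c2c(Cl)cc(NC3CCCC3)cc2Cl)ccc1O` differs from compound 3 at one place: cyclopentyl in place of (thiophen-2-yl)methyl on a nitrogen on an aromatic ring. For the measured compounds named here, the one measured step that bears on this position is a 1.1-fold lower number from compound 2 to compound 3 (0.06 log units; within the scatter), in which one aromatic group on that same nitrogen was swapped for another without a shift beyond the scatter. That step, however, exchanged one aromatic ring for another, while the step to compound 4 brings in a non-aromatic ring and drops a hydrogen-bond acceptor. With only this to go on, no shift beyond the scatter is expected in this assay from compound 3 to compound 4, with a wide range to either side. Compound 4 is therefore estimated at 9000 nM, between 3000 nM and 30000 nM, the expected step being a 1.0-fold higher number from compound 3 to compound 4 (0.02 log units; within the scatter).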

Compound 4, half-maximal inhibitory concentration: 5000 nM
Beside the measured number, compound 4's estimate is 1.8-fold (0.26 log units) above it; the measured number falls inside the stated range.
By their numbers in this assay, from the lowest: compounds 4, 3 and 2 (each within the scatter of the next). At a limit, above all of these: compound 1.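

In this assay, for the compounds shown here, the earlier compounds only exchanged one aromatic ring for another on this nitrogen, so they could not show whether an aromatic ring was needed there at all. Cyclopentyl now takes the place of (thiophen-2-yl)methyl, giving a 1.7-fold lower number from compound 3 to compound 4 (0.24 log units; within the scatter), and it takes the place of (pyridin-4-yl)methyl, giving a 2.0-fold lower number from compound 2 to compound 4 (0.29 log units; within the scatter), so neither change moves the number beyond the scatter. This position on a nitrogen on an aromatic ring therefore accepts a five-membered non-aromatic ring of carbon only, without the aromatic ring or the hydrogen-bond acceptor of (thiophen-2-yl)methyl, and nothing in the data shown explains why these three groups read alike.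

Still open, going by these compounds, is whether any group on this nitrogen can move the number beyond the scatter, for instance a longer straight carbon chain, cyclohexyl, or a chain ending in a carboxylic acid. Also open, on these data alone, is what happens with a plain amine at this place, with no ring or chain on the nitrogen.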